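The source may hold more compounds than are shown below. What is called first, only, known or untested is meant among the compounds shown, and "the series" means these compounds.

Measured so far in a functional assay on OVCAR-3 cells (Homo sapiens) for inhibition, read by sulforhodamine B assay, with a stated time of 48 h; on this read-out lower numbers stand for stronger inhibition of growth and higher numbers for weaker inhibition of growth:
compound 1 `CC1=CC[C@H](C(C)(C)NC(=S)N/N=C/c2ccccc2O)CC1` gives 11800 nM.
compound 2 `CC1=CC[C@H](C(C)(C)NC(=S)N/N=C/c2ccc(N(C)C)cc2)CC1` gives > 100000 nM, which is a limit of the assay and not a number.

Compound 2 thus sits at the limit of > 100000 nM in this assay, at which 1 of the 2 values shown sits, so its distance from compound 1 cannot be put into numbers. Compound 3 `CC1=CC[C@H](C(C)(C)NC(=S)N/N=C/c2ccc(F)cc2)CC1` carries the change (fluoro in place of dimethylamino on an aromatic carbon), fluoro in place of dimethylamino on an aromatic carbon. For the measured compounds named here, no measured pair shows this change; the expected step is a move toward stronger inhibition, an at least 3.3-fold lower number from compound 2 to compound 3 (0.52 log units; beyond the scatter), beyond the scatter but uncertain in size. Compound 3 is expected at 30000 nM, between 8000 nM and 100000 nM, with a real chance that only a limit is returned.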

Compound 3, concentration for total growth inhibition: > 100000 nM
Compound 3: a limit, no number; the forecaster's own chance of this, stated with the estimate: 35%; middle value at least 3.3-fold (0.52 log units) away from the limit.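

In this assay compound 3 returns only a limit, > 100000 nM, and not a number. Fluoro in place of dimethylamino on this aromatic carbon therefore brings no readable gain, the step between compound 2 and compound 3 cannot be read, and the values now gather at one ceiling: the limit of > 100000 nM in this assay, at which 2 of the 3 values shown sit. For the compounds shown here, the 4-fluorophenyl in place of 2-hydroxyphenyl gives an at least 8.4-fold higher number from compound 1 to compound 3 (0.92 log units; beyond the scatter), so only the 2-hydroxyphenyl of compound 1 keeps a measurable value so far.

Open, from the compounds shown here alone, is whether a hydroxy group at the place of the fluoro would return a number. Equally open, going by these compounds, is what a carboxylic acid or a primary amine on that aromatic carbon would give.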